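This account rests on a few compounds, and the source may have more. Where it says the series, first, only, none or still open, it means among the compounds named here.

Measured in an ADME assay on Akata cells (Homo sapiens) for cytotoxicity, with a stated time of 7 days; a higher number here means that more compound is tolerated, a lower number that less compound is tolerated:
Compound 1 `CNc1nc(N)nc2c1ncn2/C=C1/CC1(CO)CO`: > 24000 nM, a limit.
Compound 2 `CCCCCCCCOc1nc(N)nc2c1ncn2/C=C1/CC1(CO)CO`: > 20000 nM, a limit.
Compound 3 `Nc1nc(OCc2ccccc2)c2ncn(/C=C3/CC3(CO)CO)c2n1`: > 20000 nM, a limit.

Compound 3 has no number, only the limit > 20000 nM. The other two compounds are also limits, so the series has no numerical value yet.

The next compound is compound 4 `CCCNc1nc(N)nc2c1ncn2/C=C1/CC1(CO)CO`, with propylamino in place of benzyloxy on an aromatic carbon.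

Among the measured compounds shown here, two measured steps bear on this change, as both replace methylamino on that aromatic carbon: a step that the two limits leave unreadable from compound 1 to compound 3 and a step that the two limits leave unreadable from compound 1 to compound 2. For the measured compounds named here, neither gives a size, and no measured compound shows lower tolerance, so no step beyond the scatter is expected in this assay.

The expected step is a number no higher from compound 3 to compound 4 (the limit leaves the size open).

For compound 4 the estimate is 20000 nM, with an expected range of 7000 nM to 30000 nM.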

Compound 4, half-maximal cytotoxic concentration: > 24000 nM
Compound 4 gave a limit, no number (the forecaster's own chance of this, stated with the estimate: 75%); middle value at least 1.2-fold (0.07 log units) from the limit.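

In this assay compound 4 gives > 24000 nM, a limit, so its steps from compound 1, compound 2 and compound 3 cannot be read. As far as these compounds go, with all four values limits, the concentration at which any compound turns cytotoxic stays open, as does any effect of the group on that aromatic carbon.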